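The source may report more compounds than this note shows. Statements on the series, on what has been measured and on what is new or still open speak of the compounds shown alone.

Compound 1 `CN(C)Cc1cccc(/C=N/Nc2ncnc3sc(C(C)(C)C)cc23)n1` gives 0.381 ug/mL in a functional assay on PC-6 cells (Homo sapiens) for cytotoxicity, read by MTT assay, with a stated time of 3 days; on this read-out higher numbers stand for weaker inhibition and lower numbers for stronger inhibition. For the measured compounds named here, compound 2 `COC(=O)c1ccc(/C=N/Nc2ncnc3sc(C(C)(C)C)cc23)cc1` gives "not determined" (no result reported) in this assay, so it stands on no number at all and no step from it can be measured. Compound 3 `CC(C)(C)c1cc2c(N/N=C/c3ccccc3)ncnc2s1` differs from compound 2 by hydrogen in place of methoxycarbonyl on an aromatic carbon. Going by the values given here, with no measured pair carrying this change, the step is expected to be small, at most modestly towards weaker inhibition, and possibly inside the scatter. On that basis compound 3 is expected to give about 1.5 ug/mL in this assay, with a range from 0.3 ug/mL to 8 ug/mL.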

Compound 3, half-maximal inhibitory concentration: 6.54 ug/mL
Beside the measured number, compound 3's estimate is 4.4-fold (0.64 log units) below it, within the range that was stated.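

For the compounds shown here, compound 2 has no number in this assay, so no step to compound 3 can be read. From the compounds shown here alone, whether exchanging methoxycarbonyl for hydrogen shifts the read-out remains open. No supporting data bear on this result.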